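The source may report more compounds than this note shows. Statements on the series, on what has been measured and on what is new or still open speak of the compounds shown alone.

In an in vitro ADME assay on microsomes from liver (Homo sapiens) for metabolic stability (on this read-out higher numbers stand for fast clearance and lower numbers for slow clearance), two compounds have numbers so far:
- compound 1 `CSc1nc2nc(C)cc(Nc3ccc(S(F)(F)(F)(F)F)cc3)n2n1` gives 22.4 mL.min-1.g-1
- compound 2 `CSc1nc2nc(C)cc(Nc3ccc(C(F)(F)F)cc3)n2n1` gives 18.7 mL.min-1.g-1

Among the measured compounds shown here, compound 1 stands level with compound 2, its only neighbour on these numbers. Compound 3 `CCOc1nc2nc(C)cc(Nc3ccc(S(F)(F)(F)(F)F)cc3)n2n1` is not yet measured. It differs from compound 1 by ethoxy in place of methylsulfanyl on an aromatic carbon and keeps the rest of the structure. For the measured compounds named here, the one measured step, a 1.2-fold lower number from compound 1 to compound 2 (0.08 log units; within the scatter), changes a different group, so it offers only weak guidance here and gives no direction. Nothing beyond the scatter is therefore expected, and the expected step is a 1.1-fold lower number from compound 1 to compound 3 (0.05 log units; within the scatter) with real uncertainty around it. Compound 3 is estimated at 20 mL.min-1.g-1 (expected range 9 mL.min-1.g-1 to 45 mL.min-1.g-1).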

Compound 3, intrinsic clearance in microsomes: < 5 mL.min-1.g-1
Compound 3: only a limit was reported; the forecaster's own chance of this, stated with the estimate: 2%; middle value at least 4.0-fold (0.60 log units) from the limit.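

In this assay, the group on the aromatic carbon between two ring nitrogen atoms clearly matters: putting ethoxy in place of methylsulfanyl there gives an at least 4.4-fold lower number from compound 1 to compound 3 (0.65 log units; beyond the scatter). Among the compounds shown here, the only earlier step, a 1.2-fold lower number from compound 1 to compound 2 (0.08 log units; within the scatter), changed a different group. The number for compound 3 is a limit of the assay and not a true value: the limit of < 5 mL.min-1.g-1 in this assay, at which 1 of the 3 values shown sits.

From the compounds shown here alone, it remains open whether ethoxy would act the same way in compound 2, which carries trifluoromethyl. Going by these compounds, how a methoxy group, a longer alkoxy chain or an amine would read at this place is also open.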